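A few compounds are considered here, and "the series" means these few. Any claim that something is new, unique, unknown or untested is made for them only; others in the source may bear on it.

Two compounds of this study share a core and differ in the side chain attached to it. Compound 1 `COc1cc(C(c2ccc(O)c(OC)c2)[C@H](C)[C@H](C)CO)ccc1O` carries a short branched chain that ends in a hydroxymethyl group. In a functional assay on HeLa cells (Homo sapiens) for cytotoxicity, read by WST assay, with a stated time of 48 h (a lower number here means a stronger inhibitor, a higher number a weaker inhibitor), compound 1 gives only a limit, > 100000 nM, and not a number. Compound 2 `CCCCCCCC[C@H](C(C)C)C(c1ccc(O)c(OC)c1)c1ccc(O)c(OC)c1` carries an octyl chain and an isopropyl group instead. In this assay, going by the values given here, compound 2 gives 3100 nM, the only real number in the set, while the other value sits at the limit of > 100000 nM in this assay, at which 1 of the 2 values shown sits. Compound 3 `COc1cc(C(c2ccc(O)c(OC)c2)[C@H](CO)C(C)C)ccc1O` has not yet been measured. Compared with compound 2 it shows (hydroxy in place of heptyl on a saturated chain carbon, three bonds along the chain from two aromatic carbons). That brings compound 3 close to compound 1 in build, with a hydroxymethyl in place of the octyl. Compound 1, the closest measured relative of compound 3, reached only a limit in this assay. The step is therefore expected to be a loss well beyond the scatter, a 19-fold higher number from compound 2 to compound 3 (1.29 log units; beyond the scatter). Compound 3 is estimated at 60000 nM, with a range from 15000 nM to 150000 nM, and a fair chance that the assay reports only a limit.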

Compound 3, half-maximal inhibitory concentration: > 100000 nM
Compound 3: a limit, no number (the forecaster's own chance of this, stated with the estimate: 55%); at least 1.6-fold (0.22 log units) between middle value and limit.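

In this assay compound 3 gives > 100000 nM, which is a limit of the assay and not a number. Hydroxy in place of heptyl on a saturated chain carbon, three bonds along the chain from two aromatic carbons, which can also be read as octyl to hydroxymethyl, gives an at least 32-fold higher number from compound 2 to compound 3 (1.50 log units; beyond the scatter), so this change now has a readable step, large and beyond the scatter, and the true step may be larger still. The step from compound 1 to compound 3 cannot be read, as both ends are limits, and the two compounds with a hydroxymethyl group and no octyl chain now stand together at the edge of the assay: the limit of > 100000 nM in this assay, at which 2 of the 3 values shown sit.

This single change removes the heptyl and brings in the hydroxy at once, so the compounds shown do not separate the loss of the chain from the arrival of the hydroxy. From the compounds shown here alone, it also stays open whether a butyl or hexyl chain in place of the octyl would give a real number, and how much of the chain the value of compound 2 depends on.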